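The source may report more compounds than this note shows. Statements on the series, on what has been measured and on what is new or still open speak of the compounds shown alone.

Numbers in a functional assay on SNU-475 cells (Homo sapiens) for inhibition, read by sulforhodamine B assay, with a stated time of 72 h (on this read-out higher numbers stand for weaker inhibition and lower numbers for stronger inhibition), so far:

compound 1 `Cc1ccc(C2=Nn3c(nnc3C(C)c3ccc(CC(C)C)cc3)SC2)cc1` gives 8700 nM
compound 2 `CC(c1ccc(-c2ccccc2)c(F)c1)c1nnc2n1N=C(c1ccc(Cl)cc1Cl)CS2` gives 4700 nM
compound 3 `CC(c1ccc(-c2ccccc2)c(F)c1)c1nnc2n1N=C(c1ccc(Cl)cc1)CS2` gives 3800 nM

Compound 2 sits among three numbers that all fall within the scatter of one another: compound 3 is nearest to it and compound 1 furthest, and neither gap reaches beyond the scatter. For the measured compounds named here, the only single-point step measured so far is a 1.2-fold lower number from compound 2 to compound 3 (0.09 log units; within the scatter), and it does not move the number beyond the scatter.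

The next compound, compound 4 `CC(c1ccc(-c2ccccc2)c(F)c1)c1nnc2n1N=C(c1ccc([N+](=O)[O-])cc1)CS2`, differs from compound 2 at the same aryl group that the step from compound 2 to compound 3 touched: 4-nitrophenyl in place of 2,4-dichlorophenyl on a carbon with a double bond to nitrogen.

Going by the values given here, of the measured steps, only the one from compound 2 to compound 3 bears on this position, and it was within the scatter; no measured step introduces a nitro group or exchanges both chlorines at once, so the nitrophenyl change itself has no precedent in this set. On that basis, the expectation for compound 4 is a step of no more than the usual scatter, in either direction, expressed as a 1.1-fold higher number from compound 2 to compound 4 (0.03 log units; within the scatter). The estimate for compound 4 in this assay is therefore 5000 nM, with a range from 1800 nM to 14000 nM, the range being wide since the change is not covered by any measured step.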

Compound 4, half-maximal inhibitory concentration: 7100 nM
Beside the measured number, compound 4's estimate is 1.4-fold (0.15 log units) below it; the range from low to high includes it.
By their numbers in this assay, from the lowest: compounds 3, 2, 4 and 1 (each within the scatter of the next, the first and the last beyond it).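

In this assay the exchange of 2,4-dichlorophenyl for 4-nitrophenyl on the carbon with a double bond to nitrogen gives a 1.5-fold higher number from compound 2 to compound 4 (0.18 log units; within the scatter) and so leaves the number within the scatter, which extends the tolerance at this position from loss of a chloro group to replacement of the whole aryl pattern. The narrower exchange of nitro in place of chloro on an aromatic carbon gives a 1.9-fold higher number from compound 3 to compound 4 (0.27 log units; within the scatter) and also stays within the scatter, so compound 2, compound 3 and compound 4 cannot be told apart in this read-out, even though a nitro group with its two hydrogen-bond acceptors has entered where only chloro stood. No measurement is available that explains why these three numbers stay together.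

Open, going by these compounds, is whether an amine or a carboxylic acid on this aromatic ring, or an unsubstituted phenyl at the same carbon, would take the number beyond the scatter. On these data alone, compound 1 differs from the others in more than one place, so whether this tolerance holds with a different group on the other side of the core also remains open.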